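A Benzyl Ether in Place of an Isobutyl Ether

This account rests on a few compounds, and the source may have more. Where it says the series, first, only, none or still open, it means among the compounds named here.

Measured so far:
compound 1, `CC1=CSC(OCC(C)C)(c2ccc(Cl)cc2)c2noc(=O)n21`, gives 560 nM
compound 2, `CC1=CSC(OCC(C)C)(c2ccc(Br)cc2)c2noc(=O)n21`, gives 310 nM
compound 3, `CCCCCCOC1(c2ccc(Br)cc2)SC=C(C)n2c1noc2=O`, gives 830 nM

In a functional assay (Cavia porcellus) with Rattus norvegicus as the target (a higher number here means that more compound is needed for the effect, a lower number that less compound is needed), compound 1 holds the second highest of the three numbers. Its gap to compound 3 lies within the scatter, and so does its gap to compound 2, so the three measured compounds cannot be ranked against one another on these numbers alone.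

Compound 4, `CC1=CSC(OCc2ccccc2)(c2ccc(Cl)cc2)c2noc(=O)n21`, differs from compound 1 in one place: phenyl in place of isopropyl on a saturated chain carbon bound to an oxygen on a saturated carbon. Among the compounds with values here, only one measured step touches the same place, the change from compound 2 to compound 3, which reads a 2.7-fold higher number from compound 2 to compound 3 (0.43 log units; beyond the scatter), a modest worsening for a longer chain on that carbon. The other measured step, a 1.8-fold lower number from compound 1 to compound 2 (0.26 log units; within the scatter), concerns a different place and stays within the scatter, so it says nothing about the ether chain.

With a single step at this place, and that step pointing modestly upward, the expectation for a phenyl there is a small rise in the number, or no change beyond the scatter. The step expected here is a 1.4-fold higher number from compound 1 to compound 4 (0.15 log units; within the scatter). Compound 4 is therefore estimated at 800 nM, with a range from 350 nM to 2000 nM.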

Compound 4, half-maximal effective concentration: 740 nM
The estimate for compound 4 lay 1.1-fold (0.03 log units) above the measured number; measured number inside the range.
By their numbers in this assay, from the lowest: compounds 2, 1, 4 and 3 (each within the scatter of the next, the first and the last beyond it).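

Putting phenyl in place of isopropyl, which turns the isobutoxy group of compound 1 into the benzyloxy group of compound 4, gives a 1.3-fold higher number from compound 1 to compound 4 (0.12 log units; within the scatter) in this assay, so this change cannot be told apart from repeat-measurement noise. Within the data shown here, the earlier compounds showed this place only with saturated chains, and the one step there, a 2.7-fold higher number from compound 2 to compound 3 (0.43 log units; beyond the scatter), went beyond the scatter; the new step shows that a six-membered aromatic ring of carbon only can stand on the same carbon with no change beyond the scatter. No measured property or other outside information accounts for this result, so the numbers record the outcome without explaining it.

The compounds shown leave open whether a ring containing nitrogen, such as pyridyl, or a phenyl ring carrying an amine or a carboxylic acid, would also leave the number within the scatter at this place. Among these compounds, they also leave open whether benzyloxy would give a similar result with bromo in place of chloro on the other aromatic ring, since no pair here tests the two changes together.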